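A few compounds are considered here, and "the series" means these few. Any claim that something is new, unique, unknown or untested is made for them only; others in the source may bear on it.

Compound 2 `COc1nc2ccc(Br)cc2cc1C(c1ccccc1)n1cc(-c2ccc(OC(F)(F)F)cc2)nn1` stands highest of the two numbers in an ADME assay on HEK293 cells (Homo sapiens) for cytotoxicity, read by sulforhodamine B assay, with a stated time of 48 h, tested at 10 uM (a lower number here means less inhibition, a higher number more inhibition at the concentration tested (going by the name of the read-out)), giving 5.8%. Nearest is compound 1 `CCCCCCCc1cn(C(c2ccccc2)c2cc3cc(Br)ccc3nc2OC)nn1`, which gives 0.17% in this assay, and the step of a number 5.6 percentage points higher from compound 1 to compound 2 (within the scatter) lies within the scatter. Compound 3 `COc1nc2ccc(Br)cc2cc1C(c1ccccc1)n1cc(CO)nn1` differs from compound 2 by hydroxymethyl in place of 4-(trifluoromethoxy)phenyl on an aromatic carbon. Among the compounds with values here, only one measured step bears on this change: a number 5.6 percentage points higher from compound 1 to compound 2 (within the scatter), also an exchange on an aromatic carbon, and it stayed within the scatter. Both measured numbers sit low in this assay, so for compound 3 no step beyond the scatter is expected in either direction. Within the data shown here, the step of a number 2.8 percentage points lower from compound 2 to compound 3 (within the scatter) is expected to be small, since the one comparable exchange in this assay, a number 5.6 percentage points higher from compound 1 to compound 2 (within the scatter), moved little. Compound 3 is estimated at 3% in this assay, with a range from 0% to 12%.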

Compound 3, a percentage reported as inhibition, at one concentration (the size of the read-out at that concentration, not a potency): 11.5%
For compound 3 the middle estimate is 8.5 percentage points below the measured one; the measured number falls inside the stated range.
By their numbers in this assay, from the lowest: compounds 1, 2 and 3 (each within the scatter of the next, the first and the last beyond it).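

In this assay the exchange at this aromatic carbon of the five-membered ring gives a number 5.7 percentage points higher from compound 2 to compound 3 (within the scatter) and so does not separate hydroxymethyl from 4-(trifluoromethoxy)phenyl. Against the heptyl chain, the series now shows a number 11.3 percentage points higher from compound 1 to compound 3 (beyond the scatter) as its first step that clears the scatter, a modest one, so the position is not wholly indifferent to what it carries, though 4-(trifluoromethoxy)phenyl stays within the scatter of both other groups. Nothing on hand explains this step.

The step from compound 1 to compound 3 changes both chain length and the hydroxy end, so a hexyl chain or a longer chain ending in hydroxy would be needed to tell the two apart. From the compounds shown here alone, whether an aminomethyl group or a carboxylic acid at this carbon would move the number further also remains open.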